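Heteroaryl methyl ether variation in the series: compound 4

The source may report more compounds than this note shows. Statements on the series, on what has been measured and on what is new or still open speak of the compounds shown alone.

Measured so far in an assay on isolated protein for binding affinity to somatostatin receptor type 4 (Homo sapiens), read by radioligand binding; on this read-out lower numbers stand for stronger inhibition and higher numbers for weaker inhibition:
Compound 1 `NCCCCCOC[C@H]1O[C@@H](OCCc2c[nH]c3ccccc23)[C@H](OCc2ccccc2)[C@@H](OCc2ccccc2)[C@@H]1OCc1cccnc1` gives 360 nM
Compound 2 `NCCCCCOC[C@H]1O[C@@H](OCCc2c[nH]c3ccccc23)[C@H](OCc2ccccc2)[C@@H](OCc2ccccc2)[C@@H]1OCc1cnccn1` gives 260 nM
Compound 3 `NCCCCCOC[C@H]1O[C@@H](OCCc2c[nH]c3ccccc23)[C@H](OCc2ccccc2)[C@@H](OCc2ccccc2)[C@@H]1OCc1ccc(Cl)nc1` gives 1200 nM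

Compound 1 stands second highest of the three numbers in this assay. Nearest is a 1.4-fold lower number from compound 1 to compound 2 (0.14 log units; within the scatter); furthest is a 3.3-fold higher number from compound 1 to compound 3 (0.52 log units; beyond the scatter).

Compound 4 `NCCCCCOC[C@H]1O[C@@H](OCCc2c[nH]c3ccccc23)[C@H](OCc2ccccc2)[C@@H](OCc2ccccc2)[C@@H]1OCc1c[nH]cn1` is not yet measured in this assay. It differs from compound 1 in one place: 1H-imidazol-4-yl in place of pyridin-3-yl on a saturated chain carbon bound to an oxygen on a saturated carbon. Of the measured steps, the exchange of one six-membered heteroaryl for another, a 1.4-fold lower number from compound 1 to compound 2 (0.14 log units; within the scatter), stays within the scatter, while adding chloro, a 3.3-fold higher number from compound 1 to compound 3 (0.52 log units; beyond the scatter), and the combined change a 4.6-fold higher number from compound 2 to compound 3 (0.66 log units; beyond the scatter) both give modest increases. For the measured compounds named here, no measured step introduces a five-membered ring or a hydrogen-bond donor at this position, so the imidazolyl step has no close precedent here; the series so far tolerates small changes of the heteroaryl group with little movement and penalises the chloro addition modestly. Compound 4 is therefore expected near 450 nM, with a range from 150 nM to 1400 nM. This corresponds to an expected 1.3-fold higher number from compound 1 to compound 4 (0.10 log units; within the scatter), judged within the scatter, with the range widened for the untested five-membered ring.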

Compound 4, inhibition constant: 1040 nM
Compound 4: middle estimate off by 2.3-fold (0.36 log units), on the low side; the range from low to high includes it.
By their numbers in this assay, from the lowest: compounds 2 and 1 (each within the scatter of the next); then compounds 4 and 3 (each within the scatter of the next).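

In this assay, the heteroaryl group at this position proves less freely exchangeable than the swap between the two six-membered rings suggested: a change of heteroaryl alone, with no chloro added, moves the number beyond the scatter, both for 1H-imidazol-4-yl in place of pyridin-3-yl (a 2.9-fold higher number from compound 1 to compound 4 (0.46 log units; beyond the scatter)) and in place of pyrazin-2-yl (a 4.0-fold higher number from compound 2 to compound 4 (0.60 log units; beyond the scatter)). For the compounds shown here, the five-membered ring stands level with the 6-chloropyridin-3-yl group (a 1.2-fold lower number from compound 3 to compound 4 (0.06 log units; within the scatter)), so two structurally different exchanges on this saturated chain carbon end within the scatter of each other, while the ring size and the hydrogen-bond donor count change together in the one step and cannot be told apart here. Nothing available explains this result.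

Open, on these data alone, is which of those two differences carries the step, a question that a 1-methylimidazol-4-yl or a furan-2-yl group at this position would address. Also open, as far as these compounds go, is whether the same step holds with a shorter amine chain on the shared core.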